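This account rests on a few compounds, and the source may have more. Where it says the series, first, only, none or still open, it means among the compounds named here.

Working notes on the series. For the measured compounds named here, compound 1 `Cc1ccccc1Nc1nc(Nc2cc(Cl)ccn2)ncc1Cl` and compound 2 `COc1ccc(CNc2nc(Nc3ccc(N4CCN(C)CC4)cn3)ncc2Cl)cc1` are the two measured members. In a functional assay on MDA-MB-231 cells (Homo sapiens) for inhibition, read by CCK-8 assay, with a stated time of 48 h (on this read-out higher numbers stand for weaker inhibition of growth and lower numbers for stronger inhibition of growth), compound 1 gives 52400 nM, while compound 2 gives 14900 nM, the lowest of the two numbers, with compound 1 the nearest and beyond the scatter. Compound 3 `CC(C)c1ccccc1Nc1nc(Nc2ccc(N3CCN(C)CC3)cn2)ncc1Cl` is not yet measured. It differs from compound 2 in one place: 2-isopropylphenyl in place of 4-methoxybenzyl on a nitrogen on an aromatic ring. Going by the values given here, no measured pair isolates this change, so the step in this assay is expected to be small, at most modestly downward and likely within the scatter, giving a 1.5-fold lower number from compound 2 to compound 3 (0.17 log units; within the scatter). Compound 3 is expected at 10000 nM, within 2000 nM to 50000 nM.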

Compound 3, concentration for 50% growth inhibition: 4090 nM
The estimate for compound 3 lay 2.4-fold (0.39 log units) above the measured number; measured number inside the range.
By their numbers in this assay, from the lowest: compound 3; then compound 2; then compound 1.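

In this assay, (2-isopropylphenyl)amino in place of (4-methoxybenzyl)amino gives a 3.6-fold lower number from compound 2 to compound 3 (0.56 log units; beyond the scatter), so the group on this nitrogen matters for the read-out. The two groups match in heavy-atom count and each holds one six-membered aromatic ring of carbon only, yet they differ in hydrogen-bond acceptors, with one leaving and none entering. Nothing available explains the step.

On these data alone, whether the step belongs to the isopropyl, the methoxy or the benzyl arrangement stays open. Plain phenyl and plain benzyl on this nitrogen would separate these.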